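Swapping the Ethynyl-Linked Thiophene for a Direct Thiophene

The source may report more compounds than this note shows. Statements on the series, on what has been measured and on what is new or still open speak of the compounds shown alone.

Compound 2 `Nc1ncnn2c([C@@H]3O[C@H](CO)[C@@H](O)[C@H]3O)cc(C#Cc3cccs3)c12` carries a 2-(thiophen-2-yl)ethynyl group on the shared core. In a functional assay on HL-60 cells (Homo sapiens) for antiproliferative activity, with a stated time of 72 h (on this read-out lower numbers stand for stronger inhibition and higher numbers for weaker inhibition), compound 2 gives only a limit of the assay, > 100000 nM. Compound 1 `Nc1ncnn2c([C@@H]3O[C@H](CO)[C@@H](O)[C@H]3O)cc(C#Cc3ccc(F)cc3)c12` gives only a limit as well, > 100000 nM. Compound 3 `Nc1ncnn2c([C@@H]3O[C@H](CO)[C@@H](O)[C@H]3O)cc(-c3ccccc3F)c12` gives only a limit too, > 100000 nM. Compound 4 `Nc1ncnn2c([C@@H]3O[C@H](CO)[C@@H](O)[C@H]3O)cc(-c3ccsc3)c12` is not yet measured; it differs from compound 2 in this way: thiophen-3-yl in place of 2-(thiophen-2-yl)ethynyl on an aromatic carbon. The measured steps that bear on this change are a step that the two limits leave unreadable from compound 2 to compound 3, a step that the two limits leave unreadable from compound 1 to compound 3 and a step that the two limits leave unreadable from compound 1 to compound 2, each unreadable because of the limit of > 100000 nM in this assay, at which 3 of the 3 values shown sit. For the measured compounds named here, no measured step gives a direction, and because the limit of > 100000 nM in this assay, at which 3 of the 3 values shown sit, the step of a number no higher from compound 2 to compound 4 (the limit leaves the size open) is expected to leave compound 4 at that same limit. Compound 4 is estimated at 100000 nM, with a range from 30000 nM to 300000 nM.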

Compound 4, half-maximal inhibitory concentration: 37300 nM
The estimate for compound 4 lay 2.7-fold (0.43 log units) above the measured number; the measured number falls inside the stated range.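

Thiophen-3-yl gives the first measurable number at this position in this assay, with an at least 2.6-fold lower number from compound 2 to compound 4 (0.42 log units; beyond the scatter). Against the other two groups, the result is an at least 2.6-fold lower number from compound 3 to compound 4 (0.42 log units; beyond the scatter) and an at least 2.6-fold lower number from compound 1 to compound 4 (0.42 log units; beyond the scatter). The true sizes of these steps stay open, and the steps among compounds 1, 2 and 3 cannot be read, because those three compounds sit at a limit: the limit of > 100000 nM in this assay, at which 3 of the 4 values shown sit.

Compound 4 differs from compound 2 both in losing the triple bond and in how its thiophene is attached, and these two changes remain unseparated. Going by these compounds, whether a directly attached thiophen-2-yl, an amine or a short alkyl chain at this carbon would lower the number further also remains open.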